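Anilino variation on the shared core: methyl removal

This account rests on a few compounds, and the source may have more. Where it says the series, first, only, none or still open, it means among the compounds named here.

Compound 2 `Cc1cccc(Nc2nc(SCc3cn(Cc4ccccc4Cl)nn3)nc(-c3ccccc3)c2C#N)c1` gives the highest number of the two measured in a functional assay on MGC-803 cells (Homo sapiens) for inhibition, read by MTT assay, with a stated time of 72 h (a lower number here means a stronger inhibitor, a higher number a weaker inhibitor), at 16200 nM; compound 1 `COc1ccc(Nc2nc(SCc3cn(Cc4ccccc4Cl)nn3)nc(-c3ccccc3)c2C#N)cc1` gives 7560 nM, and a 2.1-fold higher number from compound 1 to compound 2 (0.33 log units; beyond the scatter) marks the modest gap between them. Compound 3 `N#Cc1c(Nc2ccccc2)nc(SCc2cn(Cc3ccccc3Cl)nn2)nc1-c1ccccc1` differs from compound 2 by hydrogen in place of methyl on an aromatic carbon. Among the compounds with values here, only that single measured step bears on the new change, and it concerns a different replacement, so there is no direct precedent for removing the methyl. The step is therefore expected to stay small in this assay, with no clear direction, a 1.2-fold lower number from compound 2 to compound 3 (0.06 log units; within the scatter). Compound 3 is expected at 14000 nM, within 6000 nM to 35000 nM.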

Compound 3, half-maximal inhibitory concentration: > 64000 nM
Compound 3: only a limit was reported; the forecaster's own chance of this, stated with the estimate: 10%; middle value at least 4.5-fold (0.66 log units) away from the limit.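

Compound 3 gives only a limit in this assay, not a number: the limit of > 64000 nM in this assay, at which 1 of the 3 values shown sits. Within the data shown here, with the anilino ring left bare, hydrogen in place of methyl gives an at least 3.9-fold higher number from compound 2 to compound 3 (0.59 log units; beyond the scatter) and hydrogen in place of methoxy gives an at least 8.4-fold higher number from compound 1 to compound 3 (0.92 log units; beyond the scatter), each larger than the one earlier step. A substituent on this ring, whether methyl or methoxy, therefore goes with a measurable number here, and the bare ring does not.

Going by these compounds, how far compound 3 lies past its limit stays open. So does what an amine, a chlorine or a longer chain would give on this aromatic carbon.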